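Isopropyl on the side chain of compound 1

The source may hold more compounds than are shown below. What is called first, only, known or untested is meant among the compounds shown, and "the series" means these compounds.

Measured in a functional assay on HeLa cells (Homo sapiens) for cytotoxicity, read by MTT assay, with a stated time of 72 h; on this read-out higher numbers stand for weaker inhibition and lower numbers for stronger inhibition:
- compound 1 `CC(C)(C)C1=CC(=O)C=C(NCC(=O)O)C1=O`: 132000 nM
- compound 2 `CC(C)(C)C1=CC(=O)C=CC1=O`: 44100 nM

Going by the values given here, compound 1 holds the higher of the two numbers in this assay so far. Compound 3 `CC(C)[C@@H](NC1=CC(=O)C=C(C(C)(C)C)C1=O)C(=O)O` has not yet been measured. The change from compound 1 is isopropyl in place of hydrogen on a saturated chain carbon bound to an amine nitrogen and a carbonyl carbon on a saturated chain carbon bound to an amine nitrogen and a carbonyl carbon. Among the compounds with values here, no measured step touches this carbon. The nearest evidence is a 3.0-fold lower number from compound 1 to compound 2 (0.48 log units; beyond the scatter), a modest step in which the whole (carboxymethyl)amino group gives way to hydrogen. The smaller change here is therefore expected to give no step beyond the scatter, and no firm direction can be assigned. The estimate amounts to a 1.3-fold lower number from compound 1 to compound 3 (0.10 log units; within the scatter) as the expected step. Compound 3 is estimated at 105000 nM, with an expected range of 45000 nM to 240000 nM in this read-out.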

Compound 3, half-maximal inhibitory concentration: 96600 nM
The estimate for compound 3 lay 1.1-fold (0.04 log units) above the measured number; measured number inside the range.
By their numbers in this assay, from the lowest: compound 2; then compounds 3 and 1 (each within the scatter of the next).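

In this assay isopropyl in place of hydrogen on a saturated chain carbon bound to an amine nitrogen and a carbonyl carbon gives a 1.4-fold lower number from compound 1 to compound 3 (0.14 log units; within the scatter) as its whole effect. The side chain therefore accepts this branch on that carbon with no shift beyond the scatter, which a 3.0-fold lower number from compound 1 to compound 2 (0.48 log units; beyond the scatter) could not show, since that step removes the whole (carboxymethyl)amino group at once. No measurement here bears on why the number holds at this carbon.

Still open, from the compounds shown here alone, is whether a larger group on this carbon, such as phenyl or a longer chain, would also leave the number within the scatter. Also open, going by these compounds, is what an amide in place of the carboxylic acid would do on the same side chain.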